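The source may hold more compounds than are shown below. What is called first, only, known or untested is meant among the compounds shown, and "the series" means these compounds.

Measured compounds:
compound 1, `O=C(NC1CCCCC1)NS(=O)(=O)c1ccc(-n2nc(-c3ccccc3)ccc2=O)cc1`, 86.2%;
compound 2, `CCCNC(=O)NS(=O)(=O)c1ccc(-n2nc(-c3ccc(Cl)cc3)ccc2=O)cc1`, 122%;
compound 3, `CCCCNC(=O)NS(=O)(=O)c1ccc(-n2nc(-c3ccc(Cl)cc3)ccc2=O)cc1`, 100%.

In a functional assay on the whole organism (blood, strain Wistar albino) for inhibition, with Rattus norvegicus as the target, read by colorimetric assay, with stated times of 15 min and 90 min, at a dose of 20 mg/kg by the oral route (a higher number here means more inhibition at the dose given (going by the name of the read-out), a lower number less inhibition), compound 3 stands second of the three numbers: its nearest neighbour is compound 1, and compound 2 lies furthest from it on the high side. Among the compounds with values here, the one step among the measured compounds that changes the group on the amide-type nitrogen is a number 22 percentage points lower from compound 2 to compound 3 (beyond the scatter), and it bears on the present question only loosely. Within the data shown here, compound 4, `O=C(NC1CCCCC1)NS(=O)(=O)c1ccc(-n2nc(-c3ccc(Cl)cc3)ccc2=O)cc1`, differs from compound 3 by cyclohexyl in place of butyl on an amide-type nitrogen; no measured pair shows this exact change. Compound 1 carries the cyclohexyl on a core that lacks the chloro group, and its value sits below that of compound 3. Weighing these, the step is expected to be a number 12 percentage points lower from compound 3 to compound 4 (beyond the scatter), a move downwards of modest size, though one that could stay within the scatter. Compound 4 is therefore estimated at 88%, with a range from 68% to 112%.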

Compound 4, a percentage reported as inhibition, in the whole organism at one dose (the size of the read-out at that dose, not a potency): 114%
Beside the measured number, compound 4's estimate is 26 percentage points below it, and the stated range ends below it.
By their numbers in this assay, from the lowest: compound 1; then compound 3; then compounds 4 and 2 (each within the scatter of the next).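

In this assay, changing butyl to cyclohexyl on this amide-type nitrogen gives a number 14 percentage points higher from compound 3 to compound 4 (beyond the scatter), so the fall seen from the propyl to the butyl chain does not carry over to every added carbon on this nitrogen. The ring also matches the short chain, with a number 8 percentage points lower from compound 2 to compound 4 (within the scatter), which leaves propyl and cyclohexyl not separated here. Within the data shown here, with cyclohexyl now held fixed, chloro in place of hydrogen on an aromatic carbon can be read directly as a number 27.8 percentage points higher from compound 1 to compound 4 (beyond the scatter), a comparison that the earlier compounds did not allow.

Nothing available explains why the ring and the butyl chain differ on this nitrogen. On these data alone, it remains open how a longer chain such as hexyl, a smaller ring such as cyclopentyl, or a benzyl group would read on the same nitrogen.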